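Sulfonyl substituent swap: notes on cytotoxicity limits

The compounds below may be only part of what the source reports. "The series", "measured", "known", "first", "only" and "open" are said of these compounds alone.

compound 1 `O=S(=O)(c1ccc(-c2ccc3ncnc(Nc4ccc(OCc5cccc(F)c5)c(Cl)c4)c3c2)cc1)N1CCCCC1`: > 15000 nM
compound 2 `O=S(=O)(c1cccc(-c2ccc3ncnc(Nc4ccc(OCc5cccc(F)c5)c(Cl)c4)c3c2)c1)N1CCCCC1`: > 15000 nM
compound 3 `O=S(=O)(c1ccc(-c2ccc3ncnc(Nc4ccc(OCc5cccc(F)c5)c(Cl)c4)c3c2)cc1)N1CCCC1`: > 15000 nM

All entries above are limits and not numbers, and they are read in an ADME assay on HepG2 cells (Homo sapiens) for cytotoxicity, read by MTT assay, with a stated time of 48 h; on this read-out lower numbers stand for stronger inhibition and higher numbers for weaker inhibition.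

Compound 2 stands only at a limit (> 15000 nM). The whole measured set sits there too (the limit of > 15000 nM in this assay, at which 3 of the 3 values shown sit). Compound 4 `CS(=O)(=O)c1cccc(-c2ccc3ncnc(Nc4ccc(OCc5cccc(F)c5)c(Cl)c4)c3c2)c1` has methyl in place of piperidin-1-yl on a sulfonyl sulfur. Going by the values given here, the one measured step that bears on this is a step that the two limits leave unreadable from compound 1 to compound 3 and it supplies no size to carry over. No step beyond the scatter, and no direction, is therefore expected, and another limit is the likeliest report. The expected step is a step that the limit leaves unreadable from compound 2 to compound 4. For compound 4 the estimate is 20000 nM ( expected range 7000 nM to 40000 nM).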

Compound 4, half-maximal inhibitory concentration: > 15000 nM
Compound 4 ended at the assay's limit (the forecaster's own chance of this, stated with the estimate: 75%); the middle value is on the limit's open side.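

Compound 2 and compound 4 are both limits and not numbers in this assay, and no step can be read between them. Whether any substituent on the sulfonyl sulfur changes the read-out stays open, with every compound shown sitting at one entry: the limit of > 15000 nM in this assay, at which 4 of the 4 values shown sit.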